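Methylamino for methoxy on a shared thiazole-bearing core

The compounds below may be only part of what the source reports. "The series", "measured", "known", "first", "only" and "open" are said of these compounds alone.

Compound 1 `CCn1nnc(-c2sc(-c3cccc(N(C)C)c3)nc2O)n1`: 4770 nM
Compound 2 `CCn1nnc(-c2sc(-c3cccc(OC)c3)nc2O)n1`: 245 nM

In an assay on HEK293 cells for inhibition of transient receptor potential cation channel subfamily M member 8 (Homo sapiens), read by FLIPR, with stated times of 5 min and 3 min (on this read-out higher numbers stand for weaker inhibition and lower numbers for stronger inhibition), compound 2 gives the lower of the two numbers shown, and the only measured step is a 19-fold lower number from compound 1 to compound 2 (1.29 log units; beyond the scatter). Compound 3 `CCn1nnc(-c2sc(-c3cccc(NC)c3)nc2O)n1` differs from compound 2 by methylamino in place of methoxy on an aromatic carbon. That earlier step is the one that bears here: replacing a nitrogen-bearing group by methoxy gave a large gain, and methylamino returns a nitrogen, though with one methyl fewer than dimethylamino. The number is therefore expected to rise, by an estimated 4.9-fold higher number from compound 2 to compound 3 (0.69 log units; beyond the scatter), and compound 3 is expected to give 1200 nM, within 350 nM to 4500 nM.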

Compound 3, half-maximal inhibitory concentration: 1020 nM
Estimate against measurement, compound 3: 1.2-fold (0.07 log units) above, within the range that was stated.
By their numbers in this assay, from the lowest: compound 2; then compound 3; then compound 1.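

At this position on the aromatic ring, a nitrogen-bearing group is not all alike: methylamino is weaker than methoxy (a 4.2-fold higher number from compound 2 to compound 3 (0.62 log units; beyond the scatter)), yet stronger than dimethylamino (a 4.7-fold lower number from compound 1 to compound 3 (0.67 log units; beyond the scatter)). The weak result for compound 1 therefore reflects more than the nitrogen alone, since taking one methyl off that nitrogen recovers part of the loss. Nothing shown explains this order.

On these data alone, how an unsubstituted amine, a hydroxyl or an ethoxy group would compare at this place remains open. So does whether the same order holds with a different group in place of the ethyl on the shared core.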